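The source may report more compounds than this note shows. Statements on the series, on what has been measured and on what is new or still open speak of the compounds shown alone.

Working notes on the series. Going by the values given here, the shared core of compound 1 `O=C(Nc1cccc2nonc12)N1CCN(Cc2cccc(Oc3ccc(Cl)cc3)c2)CC1` carries a piperazine urea with a bicyclic aromatic group on the amide-type nitrogen, and the three measured compounds vary only that group. In an assay on isolated protein for inhibition of Fatty-acid amide hydrolase 1 (Homo sapiens), with a stated time of 60 min (a lower number here means a stronger inhibitor, a higher number a weaker inhibitor), compound 1 gives 28 nM. Compound 2 `O=C(Nc1cncc2ccccc12)N1CCN(Cc2cccc(Oc3ccc(Cl)cc3)c2)CC1` gives 6.7 nM in this assay, and compound 3 `O=C(Nc1noc2cccnc12)N1CCN(Cc2cccc(Oc3ccc(Cl)cc3)c2)CC1` gives 13 nM. Compound 2 and compound 3 cannot be separated, because their step of a 1.9-fold higher number from compound 2 to compound 3 (0.29 log units; within the scatter) lies within the scatter; compound 1 sits apart from both, with a 4.2-fold lower number from compound 1 to compound 2 (0.62 log units; beyond the scatter) and a 2.2-fold lower number from compound 1 to compound 3 (0.33 log units; beyond the scatter).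

Compound 4 `O=C(Nc1cn2ccccc2n1)N1CCN(Cc2cccc(Oc3ccc(Cl)cc3)c2)CC1` is the next variation on the same nitrogen: a group of 9 heavy atoms (7 carbon, 2 nitrogen; one five-membered aromatic ring with 2 hetero atoms, one six-membered aromatic ring with 1 hetero atom) in place of a group of 10 heavy atoms (9 carbon, 1 nitrogen; one six-membered aromatic ring of carbon only, one six-membered aromatic ring with 1 hetero atom), on an amide-type nitrogen. Among the compounds with values here, no measured step exchanges exactly these two groups. Within the data shown here, the steps that bear on it are the swaps among bicyclic aromatic groups already seen, which span a modest range in this assay, and the swap from compound 2 to compound 3, which brings in a fused five-membered ring with 2 hetero atoms and changes nothing beyond the scatter. A step of about that size, toward a higher number or none beyond the scatter, is therefore expected in this assay; the estimate for compound 4 is 14 nM (range 5 nM to 45 nM), expected as a step of a 2.1-fold higher number from compound 2 to compound 4 (0.32 log units; beyond the scatter).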

Compound 4, half-maximal inhibitory concentration: > 10000 nM
Compound 4: only a limit was reported; the forecaster's own chance of this, stated with the estimate: 0%; at least 710-fold (2.85 log units) between middle value and limit.
By their numbers in this assay, from the lowest: compounds 2 and 3 (each within the scatter of the next); then compound 1. At a limit, above all of these: compound 4.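

In this assay the amide-type nitrogen proves far less forgiving than the earlier bicyclic aromatic groups suggested, with an at least 1400-fold higher number from compound 2 to compound 4 (3.17 log units; beyond the scatter) and an at least 350-fold higher number from compound 1 to compound 4 (2.55 log units; beyond the scatter) as the two steps from groups of differing ring make-up. The most telling reading is an at least 760-fold higher number from compound 3 to compound 4 (2.88 log units; beyond the scatter) between two groups that share a heavy-atom count and a ring description, one five-membered aromatic ring with 2 hetero atoms and one six-membered aromatic ring with 1 hetero atom, so these counts alone do not separate a low number from a loss of measurable inhibition. The figure for compound 4 is a limit of the assay and not a number: the limit of > 10000 nM in this assay, at which 1 of the 4 values shown sits.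

Going by these compounds, how far compound 4 lies beyond that limit stays open, as does which difference between its group and that of compound 3 matters, the exchange of oxygen for carbon or the placement of the ring atoms. Also open, on these data alone, is how a single-ring group such as phenyl, or a saturated one such as cyclohexyl, would read on this nitrogen in this assay.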